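This account rests on a few compounds, and the source may have more. Where it says the series, first, only, none or still open, it means among the compounds named here.

Compound 1 `CCC(=O)N(C)c1ccc2[nH]c(-c3n[nH]c4ccccc34)cc2n1` is the starting point. In a functional assay on KB cells (Homo sapiens) for antiproliferative activity, read by MTT assay, with a stated time of 72 h (a higher number here means a weaker inhibitor, a lower number a stronger inhibitor), compound 1 gives 9300 nM, the second highest of the three numbers measured. Its nearest neighbour is compound 2 `COc1ccc(C(=O)N(C)c2ccc3[nH]c(-c4n[nH]c5ccccc45)cc3n2)cc1`, which gives 12900 nM; the step of a 1.4-fold higher number from compound 1 to compound 2 (0.14 log units; within the scatter) puts a 4-methoxyphenyl in place of ethyl on the carbonyl carbon and changes little. Compound 3 `CN(c1ccc2[nH]c(-c3n[nH]c4ccccc34)cc2n1)S(=O)(=O)c1ccccc1` gives 2400 nM, and the step of a 3.9-fold lower number from compound 1 to compound 3 (0.59 log units; beyond the scatter) exchanges the whole propanoyl for phenylsulfonyl on the ring nitrogen; likewise a 5.4-fold lower number from compound 2 to compound 3 (0.73 log units; beyond the scatter).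

Compound 4 `CN(C(=O)Nc1ccccc1)c1ccc2[nH]c(-c3n[nH]c4ccccc34)cc2n1` keeps the carbonyl on that nitrogen and alters only what hangs from it: anilino in place of ethyl on a carbonyl carbon. Among the measured compounds shown here, the step that most resembles this is the one from compound 1 to compound 2, where a larger group on the same carbonyl carbon stayed within the scatter. The steps toward compound 3 concern a different kind of group and bear less on it. The expected change in this assay is therefore small, a 1.2-fold lower number from compound 1 to compound 4 (0.07 log units; within the scatter), with no clear direction. Compound 4 is expected to give about 8000 nM, within a range from 3000 nM to 20000 nM.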

Compound 4, half-maximal inhibitory concentration: 32 nM
Compound 4: the middle estimate sits 250-fold (2.40 log units) above what was measured; measured number outside the range, below it.
By their numbers in this assay, from the lowest: compound 4; then compound 3; then compounds 1 and 2 (each within the scatter of the next).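

Among the compounds shown here, the carbonyl carbon turns out to be far more sensitive in this assay than the earlier compounds suggested, and an aromatic ring there is not enough on its own: a 400-fold lower number from compound 2 to compound 4 (2.61 log units; beyond the scatter), although both groups carry such a ring, and a 290-fold lower number from compound 1 to compound 4 (2.46 log units; beyond the scatter). The sulfonyl of compound 3 also proves not to be the best link on the nitrogen on an aromatic ring, as a 75-fold lower number from compound 3 to compound 4 (1.88 log units; beyond the scatter), with the phenyl ring present on both sides of that step. Nothing available explains why the anilino group, which brings a nitrogen and a hydrogen-bond donor, does so much better.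

From the compounds shown here alone, it remains open whether the gain depends on the anilino nitrogen, its hydrogen or its ring. An ethylamino group, a benzylamino group or an anilino ring bearing a methoxy or a chlorine could help to separate these parts.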